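Chloro in Place of Hydrogen on Compound 2

The source may report more compounds than this note shows. Statements on the series, on what has been measured and on what is new or still open speak of the compounds shown alone.

In a functional assay on SH-SY5Y cells (Homo sapiens) for antiproliferative activity, read by MTT assay, with a stated time of 48 h (on this read-out lower numbers stand for stronger inhibition of growth and higher numbers for weaker inhibition of growth), compound 1 `COc1ccc(N(C)c2nc(Cl)nc3c2ncn3C)cc1` gives 3400 nM, while compound 2 `COc1ccc(Cn2cnc3c(N(C)c4ccc(OC)cc4)ncnc32)cc1` gives 27000 nM, the higher of the two numbers and beyond the scatter. Compound 3 `COc1ccc(Cn2cnc3c(N(C)c4ccc(OC)cc4)nc(Cl)nc32)cc1` is unmeasured and differs from compound 2 by chloro in place of hydrogen on an aromatic carbon, with chloro in place of hydrogen on an aromatic carbon, between two ring nitrogen atoms. The expectation rests on compound 1, which carries chloro on that carbon at 3400 nM but also differs elsewhere. A step to a lower number, beyond the scatter, is expected, estimated as a 5.4-fold lower number from compound 2 to compound 3 (0.73 log units; beyond the scatter). Compound 3 is expected at 5000 nM, within a range of 1500 nM to 18000 nM.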

Compound 3, concentration for 50% growth inhibition: 31000 nM
For compound 3 the middle estimate is 6.2-fold (0.79 log units) below the measured one; the whole stated range lies below it.
By their numbers in this assay, from the lowest: compound 1; then compounds 2 and 3 (each within the scatter of the next).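

In this assay, chloro in place of hydrogen on the aromatic carbon between two ring nitrogen atoms gives a 1.1-fold higher number from compound 2 to compound 3 (0.06 log units; within the scatter) and so leaves the number within the scatter when the 4-methoxyphenyl group is present. With chloro held in place, 4-methoxyphenyl in place of hydrogen on the saturated chain carbon bound to an aromatic nitrogen goes with a 9.1-fold higher number from compound 1 to compound 3 (0.96 log units; beyond the scatter) as the one difference. Nothing measured here explains either step. Going by these compounds, whether an amine or a fluoro group on that carbon would shift the number remains open. So does whether a longer chain on the aromatic nitrogen would keep the number of compound 3.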